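The source may hold more compounds than are shown below. What is called first, only, known or untested is meant among the compounds shown, and "the series" means these compounds.

Measured in a functional assay on the whole organism (strain Wistar) with Rattus norvegicus as the target, read by paw edema; a lower number here means that less compound is needed, a higher number that more compound is needed for the effect:
- Compound 1 `CCC(=O)OCc1cc(-n2nc(C(F)(F)F)cc2-c2ccc(Br)cc2)ccc1S(N)(=O)=O`: 17 mg/kg
- Compound 2 `CCC(=O)NS(=O)(=O)c1ccc(-n2nc(C(F)(F)F)cc2-c2ccc(Br)cc2)cc1COC(=O)CC`: 12.5 mg/kg
- Compound 3 `CCC(=O)NS(=O)(=O)c1ccc(-n2nc(C(F)F)cc2-c2ccc(OC)c(C)c2)cc1CO`: 6.3 mg/kg

Compound 1 stands at the upper end of these three values, together with compound 2, which lies within the scatter of it. Compound 3 gives a lower number than compound 1, and the gap between those two exceeds the scatter.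

The step under consideration leads from compound 1 to compound 4 `CCC(=O)OCc1cc(-n2nc(C(F)(F)F)cc2-c2ccc3c(c2)CCO3)ccc1S(N)(=O)=O`. The change is a group of 9 heavy atoms (8 carbon, 1 oxygen; one five-membered non-aromatic ring with 1 hetero atom, one six-membered aromatic ring of carbon only) in place of a group of 7 heavy atoms (6 carbon, 1 bromine; one six-membered aromatic ring of carbon only), on an aromatic carbon. The 4-bromophenyl group leaves, and the core of compound 1 and its other substituents stay as they are.

Among the measured compounds shown here, only one measured step bears on this, and only indirectly. a 1.4-fold lower number from compound 1 to compound 2 (0.13 log units; within the scatter) comes from propanoyl in place of hydrogen on a sulfonamide nitrogen, a different place from the one changed here. Compound 1 and compound 3 differ in several places, so compound 3 with 6.3 mg/kg does not isolate this change. For the measured compounds named here, no measured pair tests the change itself, so no direction can be drawn from the data, and no shift beyond the scatter is expected. The expected step is a 1.1-fold lower number from compound 1 to compound 4 (0.05 log units; within the scatter). For compound 4 the estimated value is 15 mg/kg, with an expected range of 6 mg/kg to 35 mg/kg.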

Compound 4, dose for half-maximal effect: 8.5 mg/kg
For compound 4 the middle estimate is 1.8-fold (0.25 log units) above the measured one; low and high end bracket the measured number.
By their numbers in this assay, from the lowest: compounds 3, 4, 2 and 1 (each within the scatter of the next, the first and the last beyond it).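

In this assay, the step of a 2.0-fold lower number from compound 1 to compound 4 (0.30 log units; within the scatter) is the only one shown at this aromatic carbon of the five-membered aromatic ring with 2 nitrogen, and it stays within the scatter. The earlier compounds shown here all carried a large aryl group at this place but offered no pair that isolated it; this pair shows that the 4-bromophenyl group can give way to a larger group with a second, non-aromatic ring and a hydrogen-bond acceptor, losing the bromine, with no change that can be read in this assay. Nothing at hand accounts for this outcome, and the result alone cannot separate the loss of bromine from the gain of the oxygen-bearing ring.

As far as these compounds go, whether either part matters on its own remains open, and a plain phenyl, a 4-chlorophenyl or a 4-methoxyphenyl group at the same place would each bear on that question. Also open, from the compounds shown here alone, is whether the exchange behaves the same way with a propanoyl group on the sulfonamide nitrogen, or with a free hydroxymethyl group in place of the propanoate ester.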